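Amide Nitrogen Variation on the Shared Core: Compound 3

This account rests on a few compounds, and the source may have more. Where it says the series, first, only, none or still open, it means among the compounds named here.

Compound 1, `COc1cc(-c2nnc(SCC(=O)c3ccc(C)cc3)n2N)cc(OC)c1OC`: 2940 nM
Compound 2, `COc1cc(-c2nnc(SCC(=O)Nc3ccccc3C)n2N)cc(OC)c1OC`: > 100000 nM

Of the compounds shown here, two have been measured in a functional assay on HeLa cells (Homo sapiens) for antiproliferative activity, read by MTT assay, with a stated time of 48 h; on this read-out higher numbers stand for weaker inhibition and lower numbers for stronger inhibition. Compound 1 `COc1cc(-c2nnc(SCC(=O)c3ccc(C)cc3)n2N)cc(OC)c1OC` gives 2940 nM. For compound 2 `COc1cc(-c2nnc(SCC(=O)Nc3ccccc3C)n2N)cc(OC)c1OC` the read-out is only a limit of the assay, > 100000 nM. Compound 2 therefore stands at the limit of > 100000 nM in this assay, at which 1 of the 2 values shown sits, and no number is known for it. Among the compounds with values here, the one measured step, an at least 34-fold higher number from compound 1 to compound 2 (1.53 log units; beyond the scatter), exchanged the 4-methylphenyl on the carbonyl carbon for a (2-methylphenyl)amino group, so the move from ketone to aryl amide cost a great deal.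

Compound 3 `COc1cc(-c2nnc(SCC(=O)NCc3ccc(Cl)cc3)n2N)cc(OC)c1OC` keeps the amide and changes only its nitrogen substituent: 4-chlorobenzyl in place of 2-methylphenyl on an amide-type nitrogen. Within the data shown here, no measured step tells how a benzyl amide compares with an aryl amide on this core, and the starting point is itself a limit. The expected step of an at least 1.6-fold lower number from compound 2 to compound 3 (0.22 log units; that floor lies within the scatter) is therefore uncertain in both direction and size. Compound 3 is estimated at 60000 nM, in a range from 8000 nM to 150000 nM.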

Compound 3, half-maximal inhibitory concentration: > 100000 nM
Compound 3: no number, only a limit; the forecaster's own chance of this, stated with the estimate: 55%; at least 1.6-fold (0.22 log units) between middle value and limit.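

In this assay compound 3 gives > 100000 nM, which is a limit of the assay and not a number. Set against the ketone, the exchange of the 4-methylphenyl on a carbonyl carbon for (4-chlorobenzyl)amino gives an at least 34-fold higher number from compound 1 to compound 3 (1.53 log units; beyond the scatter), so the large loss is not confined to the 2-methylphenyl amide and now holds for a second substituent on the amide-type nitrogen. The step between the two amides cannot be read, because both stand at the same limit: the limit of > 100000 nM in this assay, at which 2 of the 3 values shown sit.

How far beyond that limit either amide lies remains unknown, so the compounds shown do not rank the 4-chlorobenzyl group against the 2-methylphenyl group on the amide-type nitrogen. Also open, as far as these compounds go, is whether any amide on the shared core can return a number in this assay, for instance one carrying a cyclohexyl group or a longer alkyl chain on its nitrogen, and how a carboxylic acid would read in place of the 4-methylphenyl on the carbonyl carbon.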